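This account rests on a few compounds, and the source may have more. Where it says the series, first, only, none or still open, it means among the compounds named here.

Three compounds built on one shared core were tested in a functional assay on HepG2 cells (Homo sapiens) for cytotoxicity, read by MTT assay, with a stated time of 48 h; on this read-out higher numbers stand for weaker inhibition and lower numbers for stronger inhibition. Compound 1, `COc1cc(C(=O)C2Sc3nnc(-c4cc(OC)c(OC)c(OC)c4)n3NC2c2ccco2)cc(OC)c1OC`, carries a 3,4,5-trimethoxyphenyl on the carbonyl carbon; in this assay compound 1 gives only the limit > 100000 nM, not a number. Compound 2, `COc1cc(-c2nnc3n2NC(c2ccco2)C(C(=O)c2ccccc2F)S3)cc(OC)c1OC`, bears a 2-fluorophenyl there instead; compound 2 likewise reaches only the limit > 100000 nM. Compound 3, `COc1cc(-c2nnc3n2NC(c2ccco2)C(C(=O)c2ccc(C(F)(F)F)cc2)S3)cc(OC)c1OC`, has a 4-(trifluoromethyl)phenyl on the carbonyl carbon; compound 3 also stops at the limit > 100000 nM. The three steps among them, a step that the two limits leave unreadable from compound 1 to compound 2, a step that the two limits leave unreadable from compound 1 to compound 3 and a step that the two limits leave unreadable from compound 2 to compound 3, cannot be sized because of the limit of > 100000 nM in this assay, at which 3 of the 3 values shown sit. Compound 3 thus stands nowhere distinguishable from the other two: all three sit at the same limit.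

Compound 4, `COc1cc(-c2nnc3n2NC(c2ccco2)C(C(=O)c2ccc([N+](=O)[O-])cc2)S3)cc(OC)c1OC`, differs from compound 3 by nitro in place of trifluoromethyl on an aromatic carbon. Among the measured compounds shown here, no measured step bears on this exchange directly, and the steps that swap the aryl group on the carbonyl carbon are all unreadable, so they offer no direction and no size. Compound 4 is therefore expected to behave like its neighbours, with a step from compound 3 of a number no higher from compound 3 to compound 4 (the limit leaves the size open). The estimate for compound 4 in this assay is 100000 nM, within 30000 nM to 300000 nM, with a strong chance that only a limit is reported once more.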

Compound 4, half-maximal inhibitory concentration: 87800 nM
For compound 4 the middle estimate is 1.1-fold (0.06 log units) above the measured one, and the stated range covers the measured number.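

With 4-nitrophenyl on the carbonyl carbon, compound 4 is the first of these compounds to give a number rather than a limit in this assay, which gives the steps to it a direction: an at least 1.1-fold lower number from compound 3 to compound 4 (0.05 log units; that floor lies within the scatter), an at least 1.1-fold lower number from compound 2 to compound 4 (0.05 log units; that floor lies within the scatter) and an at least 1.1-fold lower number from compound 1 to compound 4 (0.05 log units; that floor lies within the scatter). Each of these is only a floor that lies within the scatter, so the exchange of trifluoromethyl for nitro shows that a readable value is possible with this substitution, but it does not establish a real gain over the other aryl groups. The true size of all three steps stays open because the other compounds give no number: the limit of > 100000 nM in this assay, at which 3 of the 4 values shown sit.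

From the compounds shown here alone, it remains open whether an amine or a carboxylic acid in place of the nitro group on this aromatic carbon would give a value clearly apart from compound 4. Also open, going by these compounds, is whether a change to the shared core, rather than to the aryl group on the carbonyl carbon, would move the value by more than the scatter.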